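Taking the chloro group off compound 2

This account rests on a few compounds, and the source may have more. Where it says the series, first, only, none or still open, it means among the compounds named here.

Compound 1 (`CCOC(=O)N1[C@@H]2C=C[C@@](OC)(C(=O)c3c2cc(OC)c(OC)c3OCc2ccccc2F)N1C(=O)OCC`) and compound 2 (`CCOC(=O)N1[C@@H]2C=C[C@@](OC)(C(=O)c3c2cc(OC)c(OC)c3OCc2ccc(Cl)cc2)N1C(=O)OCC`) share one core and differ in one place. In an ADME assay on KB cells (Homo sapiens) for cytotoxicity (a higher number here means that more compound is needed for the effect, a lower number that less compound is needed), compound 1 reads 99.7 ug/mL and compound 2 reads 99.9 ug/mL in a pair that lies within the usual scatter. Going by the values given here, compound 2 therefore stands level with compound 1, its only neighbour with a true number. Compound 3 (`CCCCOc1c(OC)c(OC)cc2c1C(=O)[C@]1(OC)C=C[C@H]2N(C(=O)OC)N1C(=O)OC`) reads > 300 ug/mL as a limit of the assay and not a number.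

The next compound, compound 4 (`CCOC(=O)N1[C@@H]2C=C[C@@](OC)(C(=O)c3c2cc(OC)c(OC)c3OCc2ccccc2)N1C(=O)OCC`), is made from compound 2 with hydrogen in place of chloro on an aromatic carbon, para to a large group, so 4-chlorobenzyl becomes benzyl. Among the compounds with values here, the one measured step touching this ring puts 4-chlorophenyl in place of 2-fluorophenyl. It swaps one substituted ring for another, so it does not test a bare ring directly. Resting on compound 2 and that step (a 1.0-fold higher number from compound 1 to compound 2 (0.00 log units; within the scatter)) no change beyond the scatter is expected in this assay for this removal. The estimated step (a 1.0-fold higher number from compound 2 to compound 4 (0.00 log units; within the scatter)) is expected to stay inside that scatter. Compound 4 is expected near 100 ug/mL with 45 ug/mL to 220 ug/mL as the estimated range.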

Compound 4, concentration for half-maximal effect: 215 ug/mL
The estimate for compound 4 lay 2.2-fold (0.33 log units) below the measured number, within the range that was stated.
By their numbers in this assay, from the lowest: compounds 1 and 2 (each within the scatter of the next); then compound 4. At a limit, above all of these: compound 3.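

With the chloro group gone, the read-out in this assay shows a 2.2-fold higher number from compound 2 to compound 4 (0.33 log units; beyond the scatter), and with the fluoro group gone it shows a 2.2-fold higher number from compound 1 to compound 4 (0.33 log units; beyond the scatter). The earlier step only set one halogen-bearing ring against another and found the two level, whereas these steps compare each with the plain benzyl ring, which needs more compound for the effect than either 4-chlorobenzyl or the fluorine-bearing ring of compound 1. Both steps are modest, so a halogen on this ring makes a real but small difference in these three compounds, and the scale of the read-out also has a ceiling: the limit of > 300 ug/mL in this assay, at which 1 of the 4 values shown sits.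

The compounds shown still tie each halogen to a single place on the ring, so a 4-fluorobenzyl or 2-chlorobenzyl group would be needed to tell the kind of halogen apart from where it sits. From the compounds shown here alone, it also remains open whether a non-halogen group on the same ring, such as a methyl, a methoxy or an amine, would read like the halogens or like the plain benzyl ring.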